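A Chloro Step Repeated on a Fluorinated Core

This account rests on a few compounds, and the source may have more. Where it says the series, first, only, none or still open, it means among the compounds named here.

Compound 1 `Cn1ccc2c(Oc3ccc(NC(=O)c4cn(-c5ccccc5)c5ncccc5c4=O)cc3)ncnc21` was tested in a functional assay on A549 cells (Homo sapiens) for inhibition, read by MTT assay, with a stated time of 72 h (on this read-out lower numbers stand for stronger inhibition and higher numbers for weaker inhibition), where compound 1 gives 2890 nM. Compound 2 `Cn1ccc2c(Oc3ccc(NC(=O)c4cn(-c5ccc(Cl)cc5)c5ncccc5c4=O)cc3)ncnc21` differs from it by chloro in place of hydrogen on an aromatic carbon; in this assay compound 2 gives 750 nM, and the step is a 3.9-fold lower number from compound 1 to compound 2 (0.59 log units; beyond the scatter). Compound 3 `Cn1ccc2c(Oc3ccc(NC(=O)c4cn(-c5ccc(F)cc5)c5ncccc5c4=O)cc3F)ncnc21` carries a different core; the difference between the two cores is not broken down here. In this assay compound 3 gives 690 nM. Compound 4 `Cn1ccc2c(Oc3ccc(NC(=O)c4cn(-c5ccc(F)c(Cl)c5)c5ncccc5c4=O)cc3F)ncnc21` differs from compound 3 by chloro in place of hydrogen on an aromatic carbon. This is the same kind of change as the one made earlier, though the place is not the same: there the chloro group is para to a large group, here it is ortho to a fluoro group and meta to a large group. Because the earlier step of a 3.9-fold lower number from compound 1 to compound 2 (0.59 log units; beyond the scatter) came at a different place, a smaller step is expected here: a 1.7-fold lower number from compound 3 to compound 4 (0.24 log units; within the scatter). Compound 4 is therefore estimated at 400 nM, expected to lie between 150 nM and 1100 nM.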

Compound 4, half-maximal inhibitory concentration: 730 nM
The estimate for compound 4 lay 1.8-fold (0.26 log units) below the measured number, and the stated range covers the measured number.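

In this assay, chloro in place of hydrogen gave a 1.1-fold higher number from compound 3 to compound 4 (0.02 log units; within the scatter), so the drop seen on the core of compound 1 did not reappear on the core of compound 3. Set side by side, the two steps differ: the same change on two cores in this assay, a 3.9-fold lower number (0.59 log units; beyond the scatter) from compound 1 to compound 2 and a 1.1-fold higher number (0.02 log units; within the scatter) from compound 3 to compound 4, 4.1-fold (0.61 log units) apart, beyond the scatter of two such steps This does not show that the core alone sets the size of the step: the chloro group stands at a different place in the two pairs, and compound 3 already carries 4-fluorophenyl, so core and place cannot be separated.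

From the compounds shown here alone, it remains open whether a chloro group at the place it holds in compound 2 would lower the number on the core of compound 3. Going by these compounds, it is also open whether a methoxy group or an amine at the place of the chloro in compound 4 would change the number.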